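The source may hold more compounds than are shown below. What is called first, only, known or untested is meant among the compounds shown, and "the series" means these compounds.

For the measured compounds named here, compound 1 `COc1ccc(N2C(=O)NC3(CSC4=C3C(=O)c3ncccc3C4=O)C2=O)cc1` is one of three compounds measured in a functional assay on SF-268 cells (Homo sapiens) for antiproliferative activity, read by MTT assay, with a stated time of 96 h; on this read-out higher numbers stand for weaker inhibition and lower numbers for stronger inhibition. In this assay compound 1 gives 650 nM, the lowest of the three numbers. Compound 2 `O=C1NN(c2ccc([N+](=O)[O-])cc2)C(=O)C2(CSC3=C2C(=O)c2ncccc2C3=O)N1` gives 3550 nM, and compound 3 `O=C1NN(c2ccccc2)C(=O)C2(CSC3=C2C(=O)c2ncccc2C3=O)N1` gives 2200 nM; both are built on a core that differs from the core of compound 1. Going by the values given here, the only measured step, a 1.6-fold lower number from compound 2 to compound 3 (0.21 log units; within the scatter), concerns hydrogen in place of nitro and says nothing about an exchange of the aromatic ring on the amide-type nitrogen. Compound 4 `O=C1C2=C(C(=O)c3ncccc31)C1(CS2)NC(=O)N(c2ccncc2)C1=O` differs from compound 1 by pyridin-4-yl in place of 4-methoxyphenyl on an amide-type nitrogen in a ring. Among the compounds with values here, with no measured step bearing on this swap, no move beyond the scatter is expected, though the uncertainty is wide. Compound 4 is therefore estimated at 900 nM, within 300 nM to 3000 nM, an expected step of a 1.4-fold higher number from compound 1 to compound 4 (0.14 log units; within the scatter).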

Compound 4, half-maximal inhibitory concentration: 1100 nM
Beside the measured number, compound 4's estimate is 1.2-fold (0.09 log units) below it; the range from low to high includes it.
By their numbers in this assay, from the lowest: compounds 1, 4, 3 and 2 (each within the scatter of the next, the first and the last beyond it).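

Exchanging 4-methoxyphenyl for pyridin-4-yl on this amide-type nitrogen gives a 1.7-fold higher number from compound 1 to compound 4 (0.23 log units; within the scatter) in this assay, so the two compounds cannot be told apart here. For the compounds shown here, this is the first measured step at this position on the core of compound 1, and it shows that a ring with one hetero atom can stand in place of the carbon-only ring without a move beyond the scatter. No measured evidence bears on this result. As far as these compounds go, whether an amine, a carboxylic acid or a longer chain in this place would leave the number in the same range remains open. So does whether this swap would give a similar step on the core of compound 3.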